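A few compounds are considered here, and "the series" means these few. Any claim that something is new, unique, unknown or untested is made for them only; others in the source may bear on it.

Measured compounds in a functional assay on CHO cells for positive allosteric modulation of metabotropic glutamate receptor 2 (Homo sapiens), read by scintillation counting and GTPgammaS binding, with a stated time of 30 min; on this read-out higher numbers stand for an effect only at larger amounts of compound and lower numbers for an effect already at smaller amounts:
- compound 1 `Cc1cc(Oc2ccc(-c3ccn(CC4CC4)c(=O)c3C#N)cc2)ccn1`: 832 nM
- compound 2 `CCCCn1ccc(-c2ccc(Oc3cccnc3C)cc2)c(C#N)c1=O`: 347 nM
- compound 3 `Cc1ncccc1Oc1ccc(-c2ccn(CCC(C)C)c(=O)c2C#N)cc1`: 275 nM

Compound 3 gives the lowest number of the three in this assay, but its gap to compound 2 is within the scatter, so the two cannot be ordered. Compound 1 stands clearly apart from compound 3, beyond the scatter; compound 1 differs from compound 3 in more than one place, so no single step accounts for that gap.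

The next compound, compound 4 `Cc1ncccc1Oc1ccc(-c2ccn(CC3CC3)c(=O)c2C#N)cc1`, differs from compound 3 by cyclopropyl in place of isobutyl on a saturated chain carbon bound to an aromatic nitrogen. For the measured compounds named here, no measured step carries this exact change. Going by the values given here, the one step on the chain attached to the aromatic nitrogen, a 1.3-fold lower number from compound 2 to compound 3 (0.10 log units; within the scatter), shows that reshaping this chain left the number essentially unchanged. Compound 1 carries the same chain as compound 4 but differs elsewhere in the molecule, so its value cannot be read as a guide for the chain alone.

On this basis, a step of no more than the scatter is expected, with a slight lean toward a higher number, i.e. a 1.5-fold higher number from compound 3 to compound 4 (0.16 log units; within the scatter). Compound 4 is estimated at 400 nM in this assay, with a range from 180 nM to 900 nM.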

Compound 4, half-maximal effective concentration: 1070 nM
Estimate against measurement, compound 4: 2.7-fold (0.43 log units) below; the measured number lies above the stated range.
By their numbers in this assay, from the lowest: compounds 3 and 2 (each within the scatter of the next); then compounds 1 and 4 (each within the scatter of the next).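

In this assay, for the compounds shown here, the chain on the aromatic nitrogen proves to be a position where the number can move: with the rest of the molecule unchanged, cyclopropylmethyl gives a 3.9-fold higher number from compound 3 to compound 4 (0.59 log units; beyond the scatter) against isopentyl and a 3.1-fold higher number from compound 2 to compound 4 (0.49 log units; beyond the scatter) against the butyl chain, whereas the only earlier step at this position, a 1.3-fold lower number from compound 2 to compound 3 (0.10 log units; within the scatter), did not separate the two open chains. With cyclopropylmethyl held fixed, 2-methylpyridin-3-yl in place of 2-methylpyridin-4-yl on the oxygen gives a 1.3-fold higher number from compound 1 to compound 4 (0.11 log units; within the scatter), so this swap shows no readable effect and the value of compound 1 now sits with that of compound 4 rather than apart from it as a matter of the aryl ether. Nothing available here speaks to why cyclopropylmethyl differs from the open chains.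

Still open, as far as these compounds go, is whether the three-membered ring or the smaller chain goes with the higher number, which a propyl or a cyclobutylmethyl chain on the aromatic nitrogen would help to separate. Also open, from the compounds shown here alone, is how a longer chain such as hexyl, or a chain ending in an amine, would read at this position, and whether the 2-methylpyridin-4-yl ether would follow the same chain steps.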